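Replacing one hydroxy of compound 3 with methyl

A few compounds are considered here, and "the series" means these few. Any claim that something is new, unique, unknown or untested is made for them only; others in the source may bear on it.

Compound 1 `OC[C@H]1O[C@@H](n2cnc3c(NCc4ccc(Br)cc4)ncnc32)[C@H](O)[C@@H]1O` gives > 166000 nM as a limit
Compound 2 `COc1cccc(CNc2ncnc3c2ncn3[C@@H]2O[C@H](CO)[C@@H](O)[C@H]2O)c1OC` gives > 166000 nM as a limit
Compound 3 `OC[C@H]1O[C@@H](n2cnc3c(NCc4cccc(O)c4O)ncnc32)[C@H](O)[C@@H]1O` gives 5200 nM as a number

All three values come from a functional assay on MCF cells (Homo sapiens) for antiproliferative activity, with a stated time of 72 h (a higher number here means a weaker inhibitor, a lower number a stronger inhibitor), and only one of them is a true measurement. Among the three, compound 3 is the only one with a number (5200 nM). Compound 1 and compound 2 both stop at the limit of > 166000 nM in this assay, at which 2 of the 3 values shown sit, and so give a limit, not a number.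

Compound 4 `Cc1cccc(CNc2ncnc3c2ncn3[C@@H]2O[C@H](CO)[C@@H](O)[C@H]2O)c1O` has not yet been measured and differs from compound 3 in one place (methyl in place of hydroxy on an aromatic carbon). This puts methyl in place of hydroxy on an aromatic carbon, ortho to a hydroxy group, so 2,3-dihydroxyphenyl becomes 2-hydroxy-3-methylphenyl.

The closest guide is the large step of an at least 31-fold lower number from compound 2 to compound 3 (1.50 log units; beyond the scatter) in which both hydroxy groups appear. The step of an at least 31-fold lower number from compound 1 to compound 3 (1.50 log units; beyond the scatter) is just as large, while the step that the two limits leave unreadable from compound 1 to compound 2 cannot be sized. Compound 4 keeps one of the two hydroxy groups, so a smaller move towards a higher number in this assay is expected, and the limit may even be reached. The estimate for compound 4 is 30000 nM as a middle value. The expected range for compound 4 runs from 6000 nM to 166000 nM in this estimate. The expected change is a 5.8-fold higher number from compound 3 to compound 4 (0.76 log units; beyond the scatter) overall.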

Compound 4, half-maximal inhibitory concentration: 6900 nM
The estimate for compound 4 lay 4.3-fold (0.64 log units) above the measured number; measured number inside the range.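

In this assay, methyl in place of hydroxy on this aromatic carbon, ortho to a hydroxy group, gives a 1.3-fold higher number from compound 3 to compound 4 (0.12 log units; within the scatter), so this one change leaves the read-out unmoved within the usual scatter. The earlier compounds showed only that 2,3-dihydroxyphenyl stood apart from 2,3-dimethoxyphenyl and 4-bromophenyl, whereas 2-hydroxy-3-methylphenyl now stands apart from them too, with an at least 24-fold lower number from compound 2 to compound 4 (1.38 log units; beyond the scatter) and an at least 24-fold lower number from compound 1 to compound 4 (1.38 log units; beyond the scatter), so among these compounds a second hydroxy group on the ring is not needed for a measurable number. The sizes of these two large steps rest on what compound 1 and compound 2 give, which is a limit and not a number: the limit of > 166000 nM in this assay, at which 2 of the 4 values shown sit.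

What the remaining hydroxy group contributes stays open, as the compounds shown all either keep it together with a neighbouring group or carry a ring with no hydroxy at all. Also open, on these data alone, is how this assay would read with an amine, a carboxylic acid or a longer chain such as ethyl at the position that now holds the methyl.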